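The source may report more compounds than this note shows. Statements on the series, on what has been measured and on what is new or still open speak of the compounds shown alone.

The study concerns a set of close relatives built on the shared core of compound 1, whose structure is `C[C@@H](Cn1ccc(-c2ccc(C#N)c(Cl)c2)n1)NC(=O)c1ccccc1`. In an ADME assay on PC-3 cells (Homo sapiens) for cytotoxicity, read by CCK-8 assay, with a stated time of 6 days (a higher number here means a weaker inhibitor, a lower number a stronger inhibitor), compound 1 gives only a limit, > 30000 nM. Compound 2, `COC(=O)/C=C/C(=O)N[C@@H](C)Cn1ccc(-c2ccc(C#N)c(Cl)c2)n1`, carries a 2-(methoxycarbonyl)ethenyl in place of the phenyl on the carbonyl carbon; in this assay compound 2 likewise returns only a limit, > 30000 nM. Compound 3, `C[C@@H](Cn1ccc(-c2ccc(C#N)c(Cl)c2)n1)Nc1cccnc1`, has a pyridin-3-yl in place of the benzoyl on the amine nitrogen. In this assay compound 3 stands at a limit as well, > 30000 nM. The three steps among these compounds, a step that the two limits leave unreadable from compound 1 to compound 2, a step that the two limits leave unreadable from compound 1 to compound 3 and a step that the two limits leave unreadable from compound 2 to compound 3, give no readable size since all three values sit at the limit of > 30000 nM in this assay, at which 3 of the 3 values shown sit.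

Compound 4, `C[C@@H](Cn1ccc(-c2ccc(C#N)c(Cl)c2)n1)Nc1cncnc1`, differs from compound 3 by pyrimidin-5-yl in place of pyridin-3-yl on an amine nitrogen. For the measured compounds named here, no measured step bears directly on this exchange, and the three steps that are known are unreadable in size. Going by the values given here, the account therefore expects no step that could be resolved, and the expected step is a number no higher from compound 3 to compound 4 (the limit leaves the size open). Compound 4 is expected to give 30000 nM in this assay, estimated to lie between 15000 nM and 60000 nM, most probably again as a limit rather than a number.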

Compound 4, half-maximal inhibitory concentration: > 30000 nM
Compound 4: no number, only a limit; the forecaster's own chance of this, stated with the estimate: 85%; the middle value sits exactly at the limit.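

No step from compound 1, compound 2 or compound 3 to compound 4 can be read in this assay, as compound 4 also gives only a limit and no number: the limit of > 30000 nM in this assay, at which 4 of the 4 values shown sit.

The compounds shown leave open how strongly any of them inhibits in this assay, and whether any exchange on the amine nitrogen changes that.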